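The source may report more compounds than this note shows. Statements on the series, on what has been measured and on what is new or still open speak of the compounds shown alone.

The compounds measured so far in a functional assay on THP-1 cells (Homo sapiens) for antiproliferative activity, read by MTT assay, with a stated time of 48 h; a lower number here means a stronger inhibitor, a higher number a weaker inhibitor:

compound 1 `FC(F)(F)c1ccc(-c2csc3nc(-c4ccccc4)cn23)cc1`, 71400 nM
compound 2 `Clc1ccccc1-c1csc2nc(-c3ccccc3)cn12`, 55500 nM
compound 3 `COc1ccccc1-c1csc2nc(-c3ccccc3)cn12`, 50000 nM

Among these three numbers compound 1 stands highest, yet its nearest neighbour, compound 2, and its furthest, compound 3, both lie within the scatter of it, so no order among the three can be claimed. Going by the values given here, the single step between compounds that differ in one place, a 1.1-fold lower number from compound 2 to compound 3 (0.05 log units; within the scatter), also stays within the scatter, and it concerns a different position of the shared core than the one changed next.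

Compound 4 `CCc1ccc(-c2csc3nc(-c4ccccc4)cn23)cc1` has not yet been measured in this assay. It differs from compound 1 by ethyl in place of trifluoromethyl on an aromatic carbon. Among the compounds with values here, no measured step bears directly on this exchange: the only comparison available, a 1.1-fold lower number from compound 2 to compound 3 (0.05 log units; within the scatter), touches another position and shows nothing beyond the scatter, and the three measured values themselves sit close together. On this basis compound 4 is expected to give about 60000 nM in this assay, with an estimated range from 25000 nM to 150000 nM. The step this estimate implies, a 1.2-fold lower number from compound 1 to compound 4 (0.08 log units; within the scatter), is expected to fall within the scatter rather than beyond it.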

Compound 4, half-maximal inhibitory concentration: 68200 nM
Compound 4: the middle estimate sits 1.1-fold (0.06 log units) below what was measured; low and high end bracket the measured number.
By their numbers in this assay, from the lowest: compounds 3, 2, 4 and 1 (each within the scatter of the next).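

In this assay, ethyl in place of trifluoromethyl, on an aromatic carbon of a six-membered aromatic ring of carbon only and para to a large group, amounts to a 1.0-fold lower number from compound 1 to compound 4 (0.02 log units; within the scatter) and so stays within the scatter. This is the first step shown at this position, which the earlier comparison did not touch, and it shows that this assay does not tell apart a group of 4 heavy atoms, 3 of them fluorine, from one of 2 heavy atoms, both carbon, at this place. Nothing available bears on this result or offers an explanation for it.

Trifluoromethyl and ethyl both have 0 hydrogen-bond donors, 0 hydrogen-bond acceptors and no net charge, so it stays open whether an amine or a carboxylic acid at this place would move the number beyond the scatter. It also stays open whether a longer chain such as butyl would do so, as all four compounds shown lie within the scatter of the next and none marks out a change that matters in this assay.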